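Removing one bromine from anilides that show no measurable inhibition

The compounds below may be only part of what the source reports. "The series", "measured", "known", "first", "only" and "open" are said of these compounds alone.

Compound 1 `COc1c(Br)cc(Br)cc1C(=O)Nc1ccccc1` and compound 2 `COc1c(Br)cccc1C(=O)Nc1ccccc1` share one core, while compound 3 `O=C(Nc1cccc(Cl)c1)c1cc(Br)cc(Br)c1` and the unmeasured compound 4 `O=C(Nc1cccc(Cl)c1)c1cccc(Br)c1` share another; the difference between the two cores is not broken down here. In an assay for inhibition of HSP60/HSP10 (Homo sapiens), with a stated time of 60 min (on this read-out higher numbers stand for weaker inhibition and lower numbers for stronger inhibition), compound 1 gives only a limit of the assay, > 100000 nM. In this assay compound 2 likewise gives only a limit, > 100000 nM. The change between them is hydrogen in place of bromo on an aromatic carbon, and the step that the two limits leave unreadable from compound 1 to compound 2 cannot be read because of the limit of > 100000 nM in this assay, at which 3 of the 3 values shown sit. In this assay compound 3 also gives only a limit, > 100000 nM. The change to compound 4 is hydrogen in place of bromo on an aromatic carbon; it is the same kind of change as that from compound 1 to compound 2, not the same, since there the place was also para to a methoxy group and meta to a group of 9 heavy atoms, whereas here it is meta to a large group. With every measured compound sitting at the limit, the step from compound 3 to compound 4 is expected to be a step that the limit leaves unreadable from compound 3 to compound 4. Compound 4 is therefore estimated at 150000 nM, most likely again reported as a limit.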

Compound 4, half-maximal inhibitory concentration: > 100000 nM
Compound 4: no number, only a limit (the forecaster's own chance of this, stated with the estimate: 90%); the middle value lies beyond the limit too.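

Compound 3 and compound 4 both sit at a limit rather than a number in this assay, so the step from one to the other cannot be read: the limit of > 100000 nM in this assay, at which 4 of the 4 values shown sit.

The compounds shown leave open whether hydrogen in place of bromo changes inhibition on either core at all, and by how much.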